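Fluoro for Chloro on a Benzylsulfanyl Arm

A few compounds are considered here, and "the series" means these few. Any claim that something is new, unique, unknown or untested is made for them only; others in the source may bear on it.

Of the compounds shown here, three built on one shared core have been measured in a functional assay on the whole organism (artery, strain albino) with Rattus norvegicus as the target, with a stated time of 15 min, at a dose of 10 mg/kg by the oral route; a higher number here means more inhibition at the dose given (going by the name of the read-out), a lower number less inhibition. Compound 1 `CC1=C(C(=O)Nc2ccc(Br)cc2)C(c2ccc(Cl)cc2Cl)N=C(SCc2ccc(Cl)cc2)N1` gives 4.1% in this assay. Compound 2 `CC1=C(C(=O)Nc2ccc(Br)cc2)C(c2ccc(Cl)cc2Cl)N=C(SCc2ccc(F)cc2)N1` carries the change fluoro in place of chloro on an aromatic carbon relative to compound 1, and in this assay compound 2 gives 3.6%, so that the step reads a number 0.5 percentage points lower from compound 1 to compound 2 (within the scatter). Compound 3 `CC1=C(C(=O)Nc2ccc([N+](=O)[O-])cc2)C(c2ccc(Br)cc2)N=C(SCc2ccc(Cl)cc2)N1` gives 3.1% in this assay; its value and those of compound 1 and compound 2 all sit within the scatter of one another, so no order among them can be read. The difference between the core of compound 1 and the core of compound 3 is not broken down here.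

Compound 4 `CC1=C(C(=O)Nc2ccc([N+](=O)[O-])cc2)C(c2ccc(Br)cc2)N=C(SCc2ccc(F)cc2)N1` has not yet been measured in this assay. It differs from compound 3 by fluoro in place of chloro on an aromatic carbon, the same change that turns compound 1 into compound 2. Because the earlier step of a number 0.5 percentage points lower from compound 1 to compound 2 (within the scatter) stayed within the scatter, the expected step for compound 4 is likewise small, a number 0.4 percentage points higher from compound 3 to compound 4 (within the scatter). Compound 4 is therefore estimated at 3.5% in this assay, with an expected range from 0% to 10%.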

Compound 4, a percentage reported as inhibition, in the whole organism at one dose (the size of the read-out at that dose, not a potency): 2.6%
Compound 4: middle estimate off by 0.9 percentage points, on the high side, and the stated range covers the measured number.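

Replacing the (4-chlorobenzyl)sulfanyl arm of compound 3 with (4-fluorobenzyl)sulfanyl gives, in this assay, a number 0.5 percentage points lower from compound 3 to compound 4 (within the scatter). Set beside the earlier step, the same change reads alike on the two cores: the same change on two cores in this assay, a number 0.5 percentage points lower (within the scatter) from compound 1 to compound 2 and a number 0.5 percentage points lower (within the scatter) from compound 3 to compound 4, 0 percentage points apart, within the scatter of two such steps. This shows that, across these two pairs, the change carried from one core to the other without any detectable difference, but since each step lies within the scatter, it does not show that fluoro in place of chloro has any effect of its own on either core, nor how the change would read on a third core.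

The compounds shown carry only chloro or fluoro on this arm, so it remains open how a methoxy group, a nitrile or an amine would read at that place, or a longer chain in place of the benzyl group. The core of compound 1 and the core of compound 3 also differ in more than one place, so the contribution of each of those differences remains unresolved.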